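Sulfanyl-linked diamino series: dichlorophenyl replacement on sulfur

The source may report more compounds than this note shows. Statements on the series, on what has been measured and on what is new or still open speak of the compounds shown alone.

Measured in a functional assay on PC-3 cells (Homo sapiens) for inhibition, read by sulforhodamine B assay, with a stated time of 48 h; a lower number here means that less compound is tolerated, a higher number that more compound is tolerated:
compound 1 `Nc1cc(N)c2nc(-c3ccccc3)c(Oc3ccc(Cl)c(Cl)c3)nc2c1`, < 100000 nM, a limit of the assay
compound 2 `Nc1cc(N)c2nc(-c3ccccc3)c(NCc3ccc(F)cc3)nc2c1`, < 100000 nM, a limit of the assay
compound 3 `COc1ccc(Sc2nc3cc(N)cc(N)c3nc2-c2ccccc2)cc1`, 19100 nM

Within the data shown here, compound 3 holds the only number in this assay; the other two values are limits, so no ordering against compound 3 can be read. The step from compound 3 to compound 4 `Nc1cc(N)c2nc(-c3ccccc3)c(Sc3ccc(Cl)c(Cl)c3)nc2c1` is 3,4-dichlorophenyl in place of 4-methoxyphenyl on a sulfur. Among the measured compounds shown here, no measured step changes the aryl group on the sulfur alone. The steps a step that the limit leaves unreadable from compound 1 to compound 3 and a step that the limit leaves unreadable from compound 2 to compound 3 both reach compound 3 from a limit, and a step that the two limits leave unreadable from compound 1 to compound 2 runs between two limits, so none of them has a readable size, due to the limit of < 100000 nM in this assay, at which 2 of the 3 values shown sit. Compound 1 carries the 3,4-dichlorophenoxy group, close to the (3,4-dichlorophenyl)sulfanyl that enters in compound 4, and its value in this assay is a limit only. Without a readable step in either direction, the step of a 1.3-fold higher number from compound 3 to compound 4 (0.12 log units; within the scatter) is expected to be none beyond the scatter, though a limit rather than a number remains possible. Compound 4 is therefore estimated at 25000 nM, within 8000 nM to 80000 nM.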

Compound 4, concentration lethal to 50% of the cells: < 100000 nM
Compound 4 gave a limit, no number; the forecaster's own chance of this, stated with the estimate: 30%; the middle value is on the limit's open side.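

Compound 4 gives < 100000 nM, a limit of the assay and not a number. No step from compound 1, compound 2 or compound 3 to compound 4 can be read, due to the following: the limit of < 100000 nM in this assay, at which 3 of the 4 values shown sit.

The compounds shown leave open whether 3,4-dichlorophenyl on the sulfur differs from 4-methoxyphenyl, and how compound 1, compound 2 and compound 4 order among themselves.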